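A Carbamate Aryl Swap on a Shared Core

The source may hold more compounds than are shown below. What is called first, only, known or untested is meant among the compounds shown, and "the series" means these compounds.

Measured compounds:
compound 1 `CC(C)=CCC/C(C)=C/CC1Cc2c(O)cc(=O)n(CCCO)c2CC1(C)C`: 28.7%
compound 2 `CC(C)=CCC/C(C)=C/CC1Cc2c(OCC=C(C)C)cc(=O)n(CCCO)c2CC1(C)C`: 30.3%
compound 3 `CC(C)=CCC/C(C)=C/CC1Cc2c(OC(=O)Nc3cccc(F)c3)cc(=O)n(CCCO)c2CC1(C)C`: 52.3%

In a functional assay on PANC-1 cells (Homo sapiens) for inhibition, read by MTT assay, with a stated time of 24 h, tested at 10 uM (a higher number here means more inhibition at the concentration tested (going by the name of the read-out), a lower number less inhibition), compound 3 gives 52.3%, the highest of the three numbers; compound 2 lies a number 22 percentage points higher from compound 2 to compound 3 (beyond the scatter) and compound 1 lies a number 23.6 percentage points higher from compound 1 to compound 3 (beyond the scatter), both gaps beyond the scatter. The step of a number 1.6 percentage points higher from compound 1 to compound 2 (within the scatter) is within the scatter.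

Compound 4 `CC(C)=CCC/C(C)=C/CC1Cc2c(OC(=O)Nc3ccc(F)c(Cl)c3)cc(=O)n(CCCO)c2CC1(C)C` differs from compound 3 in one place: 3-chloro-4-fluorophenyl in place of 3-fluorophenyl on an amide-type nitrogen. Among the measured compounds shown here, no measured step bears directly on this change, since every measured step concerns what sits on the ring oxygen, not what sits on the carbamoyl nitrogen. For the measured compounds named here, the only guidance is that the two carbamoyl steps, a number 23.6 percentage points higher from compound 1 to compound 3 (beyond the scatter) and a number 22 percentage points higher from compound 2 to compound 3 (beyond the scatter), were modest and upward, and compound 4 keeps that carbamoyl group. A small change of the aryl piece alone is therefore expected to move the number little, in either direction, most likely within the scatter.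

Compound 4 is estimated at 55%, with a range from 40% to 70%, meaning an expected step of a number 2.7 percentage points higher from compound 3 to compound 4 (within the scatter).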

Compound 4, a percentage reported as inhibition, at one concentration (the size of the read-out at that concentration, not a potency): 25%
Estimate against measurement, compound 4: 30 percentage points above; measured number below the stated range.
By their numbers in this assay, from the lowest: compounds 4, 1 and 2 (each within the scatter of the next); then compound 3.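

The aryl group on the amide-type nitrogen matters: in this assay, 3-chloro-4-fluorophenyl in place of 3-fluorophenyl gives a number 27.3 percentage points lower from compound 3 to compound 4 (beyond the scatter). Keeping the carbamoyl group is therefore not enough to hold the higher number, as the other comparisons read a number 5.3 percentage points lower from compound 2 to compound 4 (within the scatter) and a number 3.7 percentage points lower from compound 1 to compound 4 (within the scatter), which does not set compound 4 apart from the compounds with 3-methylbut-2-en-1-yl or hydrogen on the ring oxygen. No measurement shown gives a reason for the drop.

From the compounds shown here alone, it remains open whether the drop follows the added chlorine or the different place of the fluorine, a question that 3-chlorophenyl, 4-fluorophenyl or plain phenyl on the same nitrogen could help separate. These single-concentration percentages also leave the potency of each compound open.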